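A few compounds are considered here, and "the series" means these few. Any claim that something is new, unique, unknown or untested is made for them only; others in the source may bear on it.

Working notes on the series. In an in vitro functional assay on cells for agonist activity at Bombesin receptor subtype-3 (Mus musculus), read by luminescence and calcium flux (on this read-out higher numbers stand for an effect only at larger amounts of compound and lower numbers for an effect already at smaller amounts), compound 2 `O=C(O)c1ccccc1-c1ccc(CCc2ncc(Cc3ccccc3F)[nH]2)cc1` gives 9.5 nM, the lowest of the three numbers in hand. Compound 1 `CCCCc1cnc(CCCc2ccc(-c3ccccc3C(=O)O)cc2)[nH]1` gives 382 nM, and compound 3 `CCCCc1cnc(C(Cc2ccc(-c3ccccc3C(=O)O)cc2)C(C)C)[nH]1` gives 2240 nM; both gaps to compound 2 lie beyond the usual scatter, so compound 2 is the most potent of the three measured. Compound 4 `O=C(O)c1ccccc1-c1ccc(CCc2ncc(-c3ccccc3)[nH]2)cc1` has not yet been measured in this assay. It differs from compound 2 in one place: phenyl in place of 2-fluorobenzyl on an aromatic carbon. For the measured compounds named here, no measured pair isolates this change, so no direct comparison is available. The expected step is a 16-fold higher number from compound 2 to compound 4 (1.20 log units; beyond the scatter), a move toward weaker activity, resting only on the value of compound 2 at 9.5 nM. Compound 4 is estimated at 150 nM, with a range from 20 nM to 1500 nM.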

Compound 4, half-maximal effective concentration: 872 nM
Estimate against measurement, compound 4: 5.8-fold (0.76 log units) below; low and high end bracket the measured number.
By their numbers in this assay, from the lowest: compound 2; then compound 1; then compound 4; then compound 3.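

Phenyl in place of 2-fluorobenzyl on this aromatic carbon brings a 92-fold higher number from compound 2 to compound 4 (1.96 log units; beyond the scatter) and so gives the first direct reading at this position. The position is not indifferent to its group: both groups hold one six-membered aromatic ring of carbon only, with no hydrogen-bond donors or acceptors, yet the numbers lie far apart. No measurement in hand accounts for the step.

Still open, on these data alone, is whether the fluorine or the methylene of 2-fluorobenzyl carries the difference. Plain benzyl at this position would separate the two.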